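Solubility notes on an indole amide series, compound 4

A few compounds are considered here, and "the series" means these few. Any claim that something is new, unique, unknown or untested is made for them only; others in the source may bear on it.

Measured so far:
compound 1 `COc1ccc2[nH]c(C(=O)N3CC(=O)N(Cc4ccccc4)[C@@H](COC(C)(C)C)C3)cc2c1`: 65500 nM
compound 2 `COc1ccc2[nH]c(C(=O)N3CC(=O)N(Cc4ccccc4)[C@@H](COc4ccc(F)cc4)C3)cc2c1`: 17500 nM
compound 3 `COc1ccc2[nH]c(C(=O)N3CC(=O)N(Cc4ccccc4)[C@@H](CN4CCC(C(C)C)CC4)C3)cc2c1`: 12000 nM

All three numbers come from a physicochemical assay for solubility, read by spectrophotometry, in phosphate buffer, with a stated time of 2 h, at pH 7.4; a lower number here means a less soluble compound, a higher number a more soluble compound. Compound 3 stands lowest of the three in this assay, and its nearest neighbour is compound 2: the step of a 1.5-fold lower number from compound 2 to compound 3 (0.16 log units; within the scatter) lies within the scatter, so the two cannot be ordered. The furthest is compound 1, and the step of a 5.5-fold lower number from compound 1 to compound 3 (0.74 log units; beyond the scatter) is clear.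

Compound 4 `COc1ccc2[nH]c(C(=O)N3CC(=O)N(Cc4ccccc4)[C@@H](CN4CCCc5ccccc54)C3)cc2c1` differs from compound 3 in one place: 1,2,3,4-tetrahydroquinolin-1-yl in place of 4-isopropylpiperidin-1-yl on a saturated chain carbon bound to a saturated ring carbon. For the measured compounds named here, no measured step exchanges one nitrogen-linked ring for another; the only steps touching this position are a 5.5-fold lower number from compound 1 to compound 3 (0.74 log units; beyond the scatter) and a 1.5-fold lower number from compound 2 to compound 3 (0.16 log units; within the scatter). Of these, the step from compound 2 to compound 3 is the closer model, since both sides carry a ring rather than tert-butyl, and it was within the scatter. A small step is therefore expected, if any, and more likely downward than upward, given the direction of the step from compound 1 to compound 3.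

For compound 4 in this assay the estimated value is 8000 nM, within 3000 nM to 25000 nM, which would mean an expected step of a 1.5-fold lower number from compound 3 to compound 4 (0.18 log units; within the scatter).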

Compound 4, solubility: 8500 nM
The estimate for compound 4 lay 1.1-fold (0.03 log units) below the measured number, and the stated range covers the measured number.
By their numbers in this assay, from the lowest: compounds 4, 3 and 2 (each within the scatter of the next, the first and the last beyond it); then compound 1.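

In this assay, for the compounds shown here, the first exchange of one nitrogen-linked ring for another gives a 1.4-fold lower number from compound 3 to compound 4 (0.15 log units; within the scatter), so 1,2,3,4-tetrahydroquinolin-1-yl and 4-isopropylpiperidin-1-yl cannot be told apart at this position, despite the added aromatic ring of carbon only. Compound 4 does separate from the 4-fluorophenoxy compound, with a 2.1-fold lower number from compound 2 to compound 4 (0.31 log units; beyond the scatter), a step beyond the scatter that is modest in size, and the gap from the tert-butoxy compound remains clear at a 7.7-fold lower number from compound 1 to compound 4 (0.89 log units; beyond the scatter). No evidence accompanying these numbers accounts for them.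

The compounds shown leave open how a morpholin-4-yl ring or a carboxylic acid on this saturated chain carbon would read in this assay. They also leave open whether the tetrahydroquinoline result would hold with a substituent on its aromatic ring.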